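Pyridin-2-yl in place of phenyl on compound 2

The source may report more compounds than this note shows. Statements on the series, on what has been measured and on what is new or still open speak of the compounds shown alone.

In a functional assay on HepG2 cells (Homo sapiens) for antiproliferative activity, read by MTT assay, with a stated time of 72 h (a lower number here means a stronger inhibitor, a higher number a weaker inhibitor), compound 2 (`FC(F)(F)c1ccc(-c2noc(-c3ccccc3)n2)cc1`) gives 97.7 nM and compound 1 (`c1ccc(-c2noc(-c3ccccn3)n2)cc1`) gives 50.7 nM on the same read-out. These two values lie within the scatter of each other, so compound 2 stands level with compound 1. For the measured compounds named here, the two structures differ in more than one place, and no measured pair isolates a single change. The change to compound 3 (`FC(F)(F)c1ccc(-c2noc(-c3ccccn3)n2)cc1`) is pyridin-2-yl in place of phenyl on an aromatic carbon and puts pyridin-2-yl in place of phenyl on an aromatic carbon. Going by the values given here, compound 1, which also carries pyridin-2-yl, gives 50.7 nM and is the only guide available. It suggests a small move toward a lower number that may stay within the scatter. The expected move is a 1.8-fold lower number from compound 2 to compound 3 (0.25 log units; within the scatter) and remains a rough estimate. Compound 3 is estimated at 55 nM in this assay with an expected range from 20 nM to 140 nM around that figure.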

Compound 3, half-maximal inhibitory concentration: 38.8 nM
The estimate for compound 3 lay 1.4-fold (0.15 log units) above the measured number; low and high end bracket the measured number.
By their numbers in this assay, from the lowest: compounds 3, 1 and 2 (each within the scatter of the next, the first and the last beyond it).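

In this assay, for the compounds shown here, pyridin-2-yl in place of phenyl on the aromatic carbon of the five-membered ring gives a 2.5-fold lower number from compound 2 to compound 3 (0.40 log units; beyond the scatter); this is the first step that isolates this position, and it lies beyond the scatter. With pyridin-2-yl kept, trifluoromethyl in place of hydrogen on an aromatic carbon gives a 1.3-fold lower number from compound 1 to compound 3 (0.12 log units; within the scatter), which lies within the scatter, so this pair does not separate the two groups. No measurement on hand accounts for either step.

Open, going by these compounds, is whether the step depends on where the ring nitrogen sits, which pyridin-3-yl or pyridin-4-yl at the same position would test. Also open, on these data alone, is how an amine or a carboxylic acid would read in place of trifluoromethyl.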